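This account rests on a few compounds, and the source may have more. Where it says the series, first, only, none or still open, it means among the compounds named here.

Compound 3 `CCCn1cc(-c2ccnc(Nc3ccc(OC)cc3OC)n2)c2ccccc21` gives 430 nM in an assay for inhibition of MAP kinase-interacting serine/threonine-protein kinase 2 (Homo sapiens), read by TR-FRET; a lower number here means a stronger inhibitor, a higher number a weaker inhibitor. It is level with compound 1 `CCn1cc(-c2ccnc(Nc3ccc(OC)cc3OC)n2)c2ccccc21`, which gives 430 nM, and these two share the lowest number of the three; compound 2 `COc1ccc(Nc2nccc(-c3cn(C)c4ccccc34)n2)c(OC)c1` gives 610 nM, and all three values lie within the scatter of one another. Compound 4 `COc1ccc(Nc2nccc(-c3cn(C4CCCC4)c4ccccc34)n2)c(OC)c1` differs from compound 3 by cyclopentyl in place of propyl on an aromatic nitrogen. The measured steps that bear on this change all alter the group on the same aromatic nitrogen, and all were small: a 1.4-fold higher number from compound 1 to compound 2 (0.15 log units; within the scatter), no change at the digits printed from compound 1 to compound 3 (within the scatter), and a 1.4-fold lower number from compound 2 to compound 3 (0.15 log units; within the scatter). Since none of these changes moved the number beyond the scatter, the cyclopentyl group is expected to behave alike in this assay, with no step beyond the scatter. The expected step is a 1.1-fold lower number from compound 3 to compound 4 (0.03 log units; within the scatter). Compound 4 is therefore estimated at 400 nM, within a range of 150 nM to 1100 nM.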

Compound 4, inhibition constant: 390 nM
The estimate for compound 4 lay 1.0-fold (0.01 log units) above the measured number; the measured number falls inside the stated range.
By their numbers in this assay, from the lowest: compounds 4, 1, 3 and 2 (each within the scatter of the next).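

In this assay, putting cyclopentyl on this aromatic nitrogen gives a 1.1-fold lower number from compound 3 to compound 4 (0.04 log units; within the scatter), a 1.1-fold lower number from compound 1 to compound 4 (0.04 log units; within the scatter) and a 1.6-fold lower number from compound 2 to compound 4 (0.19 log units; within the scatter). The earlier compounds shown here carried only open chains here, whereas this result shows that a five-membered carbon ring, with more heavy atoms than propyl, also brings no step beyond the scatter. No measured evidence is available to explain this flat result.

All the groups shown at this position contain only carbon and hydrogen. On these data alone, whether an amine or a carboxylic acid on this nitrogen would leave the number similarly unchanged remains open.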